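Aryl replaced by acetamidoethyl chain on the ring nitrogen

The source may report more compounds than this note shows. Statements on the series, on what has been measured and on what is new or still open speak of the compounds shown alone.

Measured in an assay on CHO cells for displacement of a labelled ligand from adenosine receptor A3 (Homo sapiens), read by scintillation counting; on this read-out lower numbers stand for stronger inhibition and higher numbers for weaker inhibition:
compound 1 `CNC(=O)[C@@]12C[C@@H]1[C@@H](n1cnc3c(NCc4cccc(Cl)c4)nc(C#CCCCCc4cn(CCCCN)nn4)nc31)[C@H](O)[C@@H]2O` gives 47 nM
compound 2 `CNC(=O)[C@@]12C[C@@H]1[C@@H](n1cnc3c(NCc4cccc(Cl)c4)nc(C#CCCCCc4cn(Cc5ccc(-n6sccc6=O)cc5)nn4)nc31)[C@H](O)[C@@H]2O` gives 102 nM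
compound 3 `CNC(=O)[C@@]12C[C@@H]1[C@@H](n1cnc3c(NCc4cccc(Cl)c4)nc(C#CCCCCc4cn(-c5ccc(C(=O)O)cc5)nn4)nc31)[C@H](O)[C@@H]2O` gives 180 nM

Compound 3 has the highest number of the three. Compound 2 lies within the scatter of it; only compound 1 stands clearly below it. Compound 4 `CNC(=O)[C@@]12C[C@@H]1[C@@H](n1cnc3c(NCc4cccc(Cl)c4)nc(C#CCCCCc4cn(CCNC(C)=O)nn4)nc31)[C@H](O)[C@@H]2O` differs from compound 3 in one place: 2-acetamidoethyl in place of 4-carboxyphenyl on an aromatic nitrogen. Going by the values given here, two measured steps bear on this. Both a 2.2-fold higher number from compound 1 to compound 2 (0.34 log units; beyond the scatter) and a 3.8-fold higher number from compound 1 to compound 3 (0.58 log units; beyond the scatter) replaced a short chain on the ring nitrogen with a ring-bearing group and raised the number modestly. The present change runs the other way, a chain for an aryl group, so a modest drop in this assay is expected for compound 4, about a 2.6-fold lower number from compound 3 to compound 4 (0.41 log units; beyond the scatter). Compound 4 is therefore estimated at 70 nM, between 30 nM and 160 nM.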

Compound 4, inhibition constant: 22.3 nM
Compound 4: middle estimate off by 3.1-fold (0.50 log units), on the high side, outside the stated range (below it).
By their numbers in this assay, from the lowest: compound 4; then compound 1; then compounds 2 and 3 (each within the scatter of the next).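

In this assay, 2-acetamidoethyl on this aromatic nitrogen stands clear of both ring-bearing groups, with an 8.1-fold lower number from compound 3 to compound 4 (0.91 log units; beyond the scatter) and a 4.6-fold lower number from compound 2 to compound 4 (0.66 log units; beyond the scatter). Removing the ring does not account for the whole gain: compound 1 also carries a ring-free chain, yet the step is a 2.1-fold lower number from compound 1 to compound 4 (0.32 log units; beyond the scatter), so a ring-free chain alone does not set the number. Still open, from the compounds shown here alone, is whether chain length or the acetamido end drives that last step, which a 4-acetamidobutyl group on the same nitrogen would separate. Nothing available explains the gain.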